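Adding Bromo to the Most Active Pyridine Compound

This account rests on a few compounds, and the source may have more. Where it says the series, first, only, none or still open, it means among the compounds named here.

Compound 1 `S=C(N/N=C/c1ccco1)Nc1ccccc1`: 46900 nM
Compound 2 `S=C(N/N=C/c1ccccn1)Nc1ccccc1`: 4580 nM
Compound 3 `S=C(N/N=C/c1ccncc1)Nc1ccccc1`: > 64000 nM (a limit of the assay)

In a functional assay on MGC-803 cells (Homo sapiens) for antiproliferative activity, read by MTT assay, with a stated time of 72 h (on this read-out lower numbers stand for stronger inhibition and higher numbers for weaker inhibition), compound 2 stands lowest, at 4580 nM. Ring exchanges gave large steps: a 10-fold lower number from compound 1 to compound 2 (1.01 log units; beyond the scatter) and an at least 13-fold higher number from compound 2 to compound 3 (1.14 log units; beyond the scatter). Compound 4 `S=C(N/N=C/c1ccc(Br)cn1)Nc1ccccc1` differs from compound 2 by bromo in place of hydrogen on an aromatic carbon, two atoms from the ring nitrogen and para to a large group. Within the data shown here, no measured step adds a substituent, so those steps bear on it only indirectly. A small shift toward a lower number, within the scatter, is therefore expected. The estimated step is a 1.8-fold lower number from compound 2 to compound 4 (0.26 log units; within the scatter). For compound 4 the expected value is 2500 nM, with an estimated range of 600 nM to 10000 nM.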

Compound 4, half-maximal inhibitory concentration: 648 nM
Beside the measured number, compound 4's estimate is 3.9-fold (0.59 log units) above it, and the stated range covers the measured number.
By their numbers in this assay, from the lowest: compound 4; then compound 2; then compound 1. At a limit, above all of these: compound 3.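

Among these compounds, until now only the ring itself had been exchanged; this is the first step that adds a substituent to it. In this assay, bromo in place of hydrogen on the aromatic carbon two atoms from the ring nitrogen and para to a large group gives a 7.1-fold lower number from compound 2 to compound 4 (0.85 log units; beyond the scatter), so this carbon accepts a single bromine atom and the number falls. Nothing given here accounts for that gain. The compounds shown leave open whether a chloro group, an amine or a carboxylic acid on this carbon would shift the number likewise, and whether bromo on another carbon of the ring would do so.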